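A few compounds are considered here, and "the series" means these few. Any claim that something is new, unique, unknown or untested is made for them only; others in the source may bear on it.

Measured compounds in a functional assay on HOS-TE85 cells (Homo sapiens) for inhibition, read by CCK-8 assay, with a stated time of 72 h; on this read-out higher numbers stand for weaker inhibition and lower numbers for stronger inhibition:
Compound 1, `O=C(NCCCCn1cccn1)c1cccc(C2SCC(=O)N2c2ccccn2)c1`, gives 60.3 nM.
Compound 2, `O=C(NCCCCc1ccccc1)c1cccc(C2SCC(=O)N2c2ccccn2)c1`, gives 19.7 nM.
Compound 3, `CCOc1ccccc1N1C(=O)C(C)SC1c1cccc(C(=O)NCCCCc2ccccc2)c1`, gives 71.6 nM.

Compound 2 has the lowest number of the three, and its steps to both other compounds lie beyond the scatter. Among the compounds with values here, the only single-site step measured, a 3.1-fold lower number from compound 1 to compound 2 (0.49 log units; beyond the scatter), concerns the far end of the chain and so does not bear directly on the change now considered. Compound 4, `O=C(NCCCCc1ccccc1)c1cccc(C2SCC(=O)N2c2ccc(C3CC3)cc2)c1`, differs from compound 2 by 4-cyclopropylphenyl in place of pyridin-2-yl on an amide-type nitrogen in a ring. Within the data shown here, no measured step isolates this change; compound 3, which differs from compound 2 in more than one place, gives a higher number than compound 2. A small to modest rise in the number is therefore expected, a 2.0-fold higher number from compound 2 to compound 4 (0.31 log units; beyond the scatter). Compound 4 is estimated at 40 nM, with a range from 12 nM to 130 nM.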

Compound 4, half-maximal inhibitory concentration in the HOS-TE85 assay: 217 nM
Compound 4: middle estimate off by 5.4-fold (0.73 log units), on the low side; measured number outside the range, above it.
By their numbers in the HOS-TE85 assay, from the lowest: compound 2; then compounds 1 and 3 (each within the scatter of the next); then compound 4.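

Within the data shown here, in the HOS-TE85 assay, 4-cyclopropylphenyl in place of pyridin-2-yl on the amide-type nitrogen in the ring gives an 11-fold higher number from compound 2 to compound 4 (1.04 log units; beyond the scatter), the first evidence that this position alone strongly affects the number, and here the change weakens inhibition. In a physicochemical assay for solubility, read by turbidimetry, measured as kinetic solubility, at pH 7.4 (a higher number here means a more soluble compound, a lower number a less soluble compound), compound 2 gives 20000 nM and compound 4 gives 2000 nM, so the same change also costs measured solubility.

The compounds shown do not separate the part played by the cyclopropyl group from that of the ring nitrogen. An unsubstituted phenyl on this nitrogen would help to tell the two apart.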